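The source may hold more compounds than are shown below. What is called first, only, known or untested is meant among the compounds shown, and "the series" means these compounds.

Measured in a functional assay on MCF7 cells (Homo sapiens) for antiproliferative activity, read by MTT assay, with a stated time of 48 h (a higher number here means a weaker inhibitor, a lower number a stronger inhibitor), so far:
compound 1 `Cc1ccc(-c2nnc(NC(=O)/C=C/c3ccc(C(F)(F)F)cc3)s2)cc1` gives 1.1 ug/mL
compound 2 `O=C(/C=C/c1ccc(F)cc1)Nc1nnc(-c2ccc(Br)cc2)s1` gives 1.49 ug/mL
compound 3 `O=C(/C=C/c1ccc(F)cc1)Nc1nnc(-c2ccccc2)s1` gives 1.45 ug/mL

All three values lie within the usual scatter of one another. Compound 3 at 1.45 ug/mL therefore sits among the other two, with no order to be read from these numbers.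

The next compound to test is compound 4 `Cc1ccc(-c2nnc(NC(=O)/C=C/c3ccc(F)cc3)s2)cc1`, which is compound 3 with methyl in place of hydrogen on an aromatic carbon, para to a large group (methyl in place of hydrogen on an aromatic carbon). For the measured compounds named here, one measured step bears most directly on this change: a 1.0-fold lower number from compound 2 to compound 3 (0.01 log units; within the scatter), for hydrogen in place of bromo on an aromatic carbon. That step stays within the scatter. Compound 1 already carries the 4-methylphenyl group, though it differs elsewhere too, and its 1.1 ug/mL stays within the scatter of compound 3.

No step beyond the scatter is therefore expected in this assay, and the estimated 1.1-fold lower number from compound 3 to compound 4 (0.05 log units; within the scatter) is small. The expected value for compound 4 is 1.3 ug/mL, with an estimated range from 0.7 ug/mL to 2.4 ug/mL.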

Compound 4, half-maximal inhibitory concentration: 1.27 ug/mL
Estimate against measurement, compound 4: 1.0-fold (0.01 log units) above, and the stated range covers the measured number.
By their numbers in this assay, from the lowest: compounds 1, 4, 3 and 2 (each within the scatter of the next).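

In this assay, the new result adds methyl to the groups tried on this aromatic carbon, para to a large group (a 1.1-fold lower number from compound 3 to compound 4 (0.06 log units; within the scatter)), and replacing bromo with methyl at the same place gives a similar picture (a 1.2-fold lower number from compound 2 to compound 4 (0.07 log units; within the scatter)), so hydrogen, bromo and methyl cannot be told apart here. With the 4-methylphenyl group held fixed, the group at the other end of the molecule can also be exchanged, fluoro in place of trifluoromethyl, without leaving the scatter (a 1.2-fold higher number from compound 1 to compound 4 (0.06 log units; within the scatter)). No measurement shown gives a reason for these numbers.

Going by these compounds, it remains open whether an amine or a carboxylic acid on this aromatic carbon would give a step beyond the scatter. A longer chain in place of methyl is equally untested among the compounds shown.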